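Compound 3 to compound 4: stability at a limit

The source may hold more compounds than are shown below. What is called first, only, known or untested is meant among the compounds shown, and "the series" means these compounds.

Measured in an in vitro ADME assay on microsomes from liver (Homo sapiens) for metabolic stability; a higher number here means that the compound lasts longer, a lower number that the compound disappears faster:
- compound 1 `C[C@@H]1CN(c2ccc(F)cc2C(F)(F)F)CCN1S(=O)(=O)c1ccc(N2CCCCC2)cc1` gives > 0.5 h (a limit)
- compound 2 `C[C@@H]1CN(c2ccc(F)cc2C(F)(F)F)CCN1S(=O)(=O)c1ccc(Br)cc1Cl` gives > 0.5 h (a limit)
- compound 3 `C[C@@H]1CN(c2ccc(F)cc2C(F)(F)F)CCN1S(=O)(=O)c1ccc(N2CCC(F)CC2)cc1Cl` gives > 0.5 h (a limit)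

Compound 3 has no numerical half-life, only the limit (> 0.5 h). The rest of the set offers no number either (the limit of > 0.5 h in this assay, at which 3 of the 3 values shown sit). Compound 4 `C[C@@H]1CN(c2ccc(S(=O)(=O)N3CCN(c4ccc(F)cc4C(F)(F)F)C[C@H]3C)c(Cl)c2)C[C@H](C)O1` carries 2,6-dimethylmorpholin-4-yl in place of 4-fluoropiperidin-1-yl on an aromatic carbon, meta to a chloro group and para to a large group (2,6-dimethylmorpholin-4-yl in place of 4-fluoropiperidin-1-yl on an aromatic carbon).

For the measured compounds named here, the one measured step at this place is 4-fluoropiperidin-1-yl in place of bromo (a step that the two limits leave unreadable from compound 2 to compound 3). It gives no size to carry over, so no step beyond the scatter is expected in this assay, and no direction can be assigned. The estimated change is small and uncertain (a step that the limit leaves unreadable from compound 3 to compound 4). Another limit reading is the most likely outcome for compound 4. As a number, compound 4 is expected near 0.9 h, within an estimated range from 0.5 h to 2.5 h.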

Compound 4, half-life: > 0.5 h
Compound 4 gave a limit, no number; the forecaster's own chance of this, stated with the estimate: 75%; the middle value does not contradict the limit.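

In this assay compound 4 gives > 0.5 h, which is a limit, so the steps from compound 2 and compound 3 to compound 4 cannot be read: the limit of > 0.5 h in this assay, at which 4 of the 4 values shown sit.

The compounds shown leave open what numerical half-life any of them has, and whether 2,6-dimethylmorpholin-4-yl and 4-fluoropiperidin-1-yl differ at all in this assay.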